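The source may hold more compounds than are shown below. What is called first, only, known or untested is meant among the compounds shown, and "the series" means these compounds.

Measured so far:
compound 1 `O=C(O)c1cccc(C2CC2c2ccc(OCc3c(-c4c(Cl)cccc4Cl)noc3C3CC3)cc2Cl)c1` with 20000 nM
compound 2 `O=C(O)c1ccc(C2CC2c2ccc(OCc3c(-c4c(Cl)cccc4Cl)noc3C3CC3)cc2Cl)cc1` with 72000 nM
compound 3 `O=C(O)c1cccc([C@H]2C[C@](O)(c3ccc(OCc4c(-c5c(Cl)cccc5Cl)noc4C4CC4)cc3Cl)C2)c1` with 192000 nM

In a physicochemical assay for solubility (on this read-out higher numbers stand for higher solubility and lower numbers for lower solubility), compound 1 gives 20000 nM, while compound 2 gives 72000 nM. The change between them, (4-carboxyphenyl in place of 3-carboxyphenyl on a saturated ring carbon), produced a 3.6-fold higher number from compound 1 to compound 2 (0.56 log units; beyond the scatter). Compound 3 gives 192000 nM, the highest of the three numbers; how its core differs from that of compound 1 is not broken down here.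

Compound 4 `O=C(O)c1ccc([C@H]2C[C@](O)(c3ccc(OCc4c(-c5c(Cl)cccc5Cl)noc4C4CC4)cc3Cl)C2)cc1` has not yet been measured in this assay. It differs from compound 3 by 4-carboxyphenyl in place of 3-carboxyphenyl on a saturated ring carbon, the same kind of change as that from compound 1 to compound 2, though here the place is on a four-membered non-aromatic ring of carbon only, two ring bonds from the ring atom that bears a hydroxy group, rather than on a three-membered ring next to the ring atom that bears a large group. Resting on that one earlier step of a 3.6-fold higher number from compound 1 to compound 2 (0.56 log units; beyond the scatter), compound 4 is expected to show a 2.6-fold higher number from compound 3 to compound 4 (0.42 log units; beyond the scatter), a step of similar size. Compound 4 is therefore estimated at 500000 nM, with a likely range from 200000 nM to 1400000 nM.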

Compound 4, solubility: 192000 nM
The estimate for compound 4 lay 2.6-fold (0.42 log units) above the measured number; measured number outside the range, below it.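

In this assay, 4-carboxyphenyl in place of 3-carboxyphenyl did not give the same result on the two cores: on the three-membered ring the change gave a 3.6-fold higher number from compound 1 to compound 2 (0.56 log units; beyond the scatter) while on the four-membered ring it gave no change at the digits printed from compound 3 to compound 4 (within the scatter) and so the step seen on the core of compound 1 did not carry over to the core of compound 3. With only these two pairs, the change cannot be assigned a single size across this series, though the result does show that its outcome depends on the core it is placed on. The cores differ in both ring size and the hydroxy group, so the pairs do not show which difference matters, and nothing available bears on the result.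

From the compounds shown here alone, it remains open whether a methoxy group or an amine in place of that hydroxy group would leave the step as it stands on the core of compound 3. Going by these compounds, a tetrazole in place of the carboxylic acid is equally open.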